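The source may hold more compounds than are shown below. What is called first, only, known or untested is meant among the compounds shown, and "the series" means these compounds.

Measured in a functional assay on ECa-109 cells (Homo sapiens) for antiproliferative activity, read by MTT assay, with a stated time of 72 h; on this read-out lower numbers stand for stronger inhibition and higher numbers for weaker inhibition:
- compound 1 `CCCSc1nc(N/N=C(\C)c2ccc(O)cc2)c2nnn(Cc3ccccc3)c2n1`: 32500 nM
- compound 2 `CCCSc1nc(N/N=C(\C)c2ccc(OC)cc2)c2nnn(Cc3ccccc3)c2n1`: > 64000 nM
- compound 3 `CCCSc1nc(N/N=C(\C)c2ccccc2O)c2nnn(Cc3ccc(O)cc3)c2n1`: 15900 nM

The entry for compound 2 is a limit of the assay, not a number: the limit of > 64000 nM in this assay, at which 1 of the 3 values shown sits.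

Of the two true numbers, compound 1 has the higher one, while compound 3 sits a little lower, just beyond the usual scatter. Compound 4 `CCCSc1nc(N/N=C/c2cccs2)c2nnn(Cc3ccccc3)c2n1` has not yet been measured. It differs from compound 1 as follows: a group of 7 heavy atoms (5 carbon, 1 nitrogen, 1 sulfur; one five-membered aromatic ring with 1 hetero atom) in place of a group of 10 heavy atoms (8 carbon, 1 nitrogen, 1 oxygen; one six-membered aromatic ring of carbon only), on a nitrogen on an aromatic ring.

Within the data shown here, the only measured step, an at least 1.9-fold higher number from compound 1 to compound 2 (0.29 log units; that floor lies within the scatter), changes a different detail, so it gives little guidance on replacing a whole group. No clear shift is therefore expected in this assay, and the estimated step is a 1.1-fold lower number from compound 1 to compound 4 (0.03 log units; within the scatter). For compound 4 the expected value is 30000 nM, with an estimated range of 10000 nM to 64000 nM.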

Compound 4, half-maximal inhibitory concentration: > 64000 nM
Compound 4: no number, only a limit; the forecaster's own chance of this, stated with the estimate: 25%; at least 2.1-fold (0.32 log units) between middle value and limit.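

Replacing the whole group on the nitrogen with the smaller one, which carries a five-membered aromatic ring with 1 hetero atom and 0 hydrogen-bond donors, gives an at least 1.9-fold higher number from compound 1 to compound 4 (0.29 log units; that floor lies within the scatter) in this assay. This is a second kind of change to compound 1 that ends without a true number, and no gain in inhibition appears. As far as these compounds go, the size of the step stays unknown because the entry for compound 4 is a limit: the limit of > 64000 nM in this assay, at which 2 of the 4 values shown sit.

From the compounds shown here alone, the ring, the group size and the hydrogen-bond donor all changed together, so their separate shares remain open. Going by these compounds, whether an amine or a carboxylic acid on the ring would lower the number is also open.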